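A few compounds are considered here, and "the series" means these few. Any claim that something is new, unique, unknown or untested is made for them only; others in the source may bear on it.

Three compounds have been measured in an ADME assay on the whole organism for cytotoxicity, with Artemia salina as the target, with a stated time of 24 h; on this read-out higher numbers stand for an effect only at larger amounts of compound and lower numbers for an effect already at smaller amounts:

Compound 1 `Cc1ccc(S(=O)(=O)NC(=O)Nc2ccccc2C(=O)/C=C/c2cccc(F)c2)cc1` — 4.13 ug/mL
Compound 2 `Cc1ccc(S(=O)(=O)NC(=O)Nc2ccccc2C(=O)/C=C/c2ccc(F)cc2)cc1` — 3.96 ug/mL
Compound 3 `Cc1ccc(S(=O)(=O)NC(=O)Nc2ccccc2C(=O)/C=C/c2ccc(Cl)cc2Cl)cc1` — 8.34 ug/mL

Compound 3 gives the highest of the three numbers. Its distance from the others is beyond the scatter on both sides: a 2.0-fold higher number from compound 1 to compound 3 (0.31 log units; beyond the scatter) and a 2.1-fold higher number from compound 2 to compound 3 (0.32 log units; beyond the scatter), each a modest step. Compounds 1 and 2, by contrast, cannot be told apart, since a 1.0-fold lower number from compound 1 to compound 2 (0.02 log units; within the scatter).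

The next compound, compound 4 `Cc1ccc(S(=O)(=O)NC(=O)Nc2ccccc2C(=O)/C=C/C=C/c2ccccc2)cc1`, is derived from compound 3 by a single change: 2-phenylethenyl in place of 2,4-dichlorophenyl on a double-bonded chain carbon bound to a double-bonded chain carbon. Within the data shown here, no measured step exchanges this group for a chain-extended phenyl, so nothing bears on it directly. Among the measured compounds shown here, the only steps that touch the same group are the two leading into compound 3, and both were modest; the one between compounds 1 and 2 stayed within the scatter. The expectation for this assay is therefore a step of no more than modest size, with the direction not settled by the data, and a lean toward a lower number is taken only because compound 3 sits at the top of the three values with 8.34 ug/mL.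

For compound 4 the estimate in this assay is 6 ug/mL, with a range of 2.5 ug/mL to 15 ug/mL, which corresponds to an expected step of a 1.4-fold lower number from compound 3 to compound 4 (0.14 log units; within the scatter).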

Compound 4, concentration for half-maximal effect: 18.2 ug/mL
Compound 4: the middle estimate sits 3.0-fold (0.48 log units) below what was measured, and the stated range ends below it.
By their numbers in this assay, from the lowest: compounds 2 and 1 (each within the scatter of the next); then compound 3; then compound 4.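

At this place, on a double-bonded chain carbon bound to a double-bonded chain carbon, 2-phenylethenyl takes the numbers in this assay higher than any of the three substituted phenyl groups did, so compound 4 now stands at the top of the series (2,4-dichlorophenyl: a 2.2-fold higher number from compound 3 to compound 4 (0.34 log units; beyond the scatter); 4-fluorophenyl: a 4.6-fold higher number from compound 2 to compound 4 (0.66 log units; beyond the scatter); 3-fluorophenyl: a 4.4-fold higher number from compound 1 to compound 4 (0.64 log units; beyond the scatter)). Among these compounds, the earlier compounds showed only that the number can shift with the halogens on a phenyl ring at this place, whereas this change swaps chlorine for carbon and brings in a double bond outside aromatic rings, and the effect is larger against either fluorophenyl group than against 2,4-dichlorophenyl. No measurement shown here accounts for this rise.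

The change in compound 4 removes the halogens and lengthens the chain together, so the compounds shown cannot say which of the two goes with the higher number. A plain phenyl group at this place would separate the two, and a chlorine-bearing 2-phenylethenyl or a longer chain such as a third double bond would show whether the rise continues.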